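Compound 4: fluoro in place of hydrogen, working notes

The source may hold more compounds than are shown below. What is called first, only, known or untested is meant among the compounds shown, and "the series" means these compounds.

Compound 1 `Cc1ccccc1NC(=O)N[C@H](C)c1ccccc1` gives the highest of the three numbers in an ADME assay on the whole organism with Oryza sativa as the target, tested at 10 uM (on this read-out higher numbers stand for a weaker effect at the one concentration tested and lower numbers for a stronger effect), with compound 1 at 99%. Compound 2 `CCc1ccccc1NC(=O)N[C@H](C)c1ccccc1` sits at 92%, a move of a number 7 percentage points lower from compound 1 to compound 2 (within the scatter). Compound 3 `C[C@@H](NC(=O)Nc1ccccc1F)c1ccccc1` gives 77%, a move of a number 22 percentage points lower from compound 1 to compound 3 (beyond the scatter), and likewise a number 15 percentage points lower from compound 2 to compound 3 (beyond the scatter). Compound 4 `Cc1cc(F)ccc1NC(=O)N[C@H](C)c1ccccc1` differs from compound 1 by fluoro in place of hydrogen on an aromatic carbon. The two measured steps that bring fluoro onto the ring do so while removing methyl or ethyl, so they bear only loosely on this change; both ran lower by a modest amount. Since the methyl stays here, a smaller downward step is expected, a number 11 percentage points lower from compound 1 to compound 4 (beyond the scatter). Compound 4 is therefore expected to give 88%, estimated between 70% and 100%.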

Compound 4, a percentage reported as activity, at one concentration (the size of the read-out at that concentration, not a potency): 94%
For compound 4 the middle estimate is 6 percentage points below the measured one; the range from low to high includes it.
By their numbers in this assay, from the lowest: compound 3; then compounds 2, 4 and 1 (each within the scatter of the next).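

Within the data shown here, the step of a number 5 percentage points lower from compound 1 to compound 4 (within the scatter) in this assay is the first here that adds fluoro while the methyl stays, at the ring carbon para to a large group and meta to a methyl group. Fluoro at this position therefore leaves the number within the scatter, whereas a number 22 percentage points lower from compound 1 to compound 3 (beyond the scatter) for fluoro in place of methyl goes beyond it. No measurement shown here accounts for this difference.

Going by these compounds, whether chloro or methoxy in place of hydrogen at this position would move the number beyond the scatter stays open.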